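Methoxy for trifluoromethyl on a potent methyl compound

The compounds below may be only part of what the source reports. "The series", "measured", "known", "first", "only" and "open" are said of these compounds alone.

Values in a functional assay (aorta) for inhibition, with Rattus norvegicus as the target; a lower number here means a stronger inhibitor, a higher number a weaker inhibitor:
- compound 1 `FC(F)(F)c1cccc(N2CCN(c3ccc(-c4ncns4)nn3)CC2)c1`: 70 nM
- compound 2 `CN(C)c1nsc(-c2ccc(N3CCN(c4cccc(C(F)(F)F)c4)CC3)nn2)n1`: 0.4 nM; 6 nM (2 entries)
- compound 3 `Cc1nsc(-c2ccc(N3CCN(c4cccc(C(F)(F)F)c4)CC3)nn2)n1`: 0.3 nM

Compound 3 holds the lower of the two single numbers, and the step that reaches it is a 230-fold lower number from compound 1 to compound 3 (2.37 log units; beyond the scatter). Compound 2 has no single number, and its entries lie far apart (the several entries of compound 2 in this assay, 0.4 nM; 6 nM (2 entries)).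

Compound 4 `COc1cccc(N2CCN(c3ccc(-c4nc(C)ns4)nn3)CC2)c1` has not been measured. It differs from compound 3 by methoxy in place of trifluoromethyl on an aromatic carbon. Going by the values given here, the only measured step, methyl in place of hydrogen on an aromatic carbon, is a different change, and compound 4 keeps that methyl. Among the compounds with values here, it therefore gives no size for this replacement, and no measured step does.

Compound 4 is expected to stay close to compound 3 (0.3 nM) in this assay, with a modest shift towards a higher number. The expected change is a 2.7-fold higher number from compound 3 to compound 4 (0.43 log units; beyond the scatter) and carries wide uncertainty. Compound 4 is estimated at 0.8 nM, with an expected range from 0.15 nM to 6 nM.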

Compound 4, half-maximal inhibitory concentration: 7 nM
Compound 4: middle estimate off by 8.8-fold (0.94 log units), on the low side; measured number above the stated range.
By their numbers in this assay, from the lowest: compound 3; then compound 4; then compound 1.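

The new result gives the first measured size for a change at this place, on an aromatic carbon meta to a large group: in this assay, methoxy in place of trifluoromethyl gives a 23-fold higher number from compound 3 to compound 4 (1.37 log units; beyond the scatter). Going by these compounds alone, the only earlier step concerned the methyl, and the new step shows that keeping this methyl does not hold compound 4 at the level of compound 3, so the group at this place also matters. One caution applies to reading single numbers in this assay, where repeat entries for one compound can lie far apart: the several entries of compound 2 in this assay, 0.4 nM; 6 nM (2 entries)

The compounds shown carry only trifluoromethyl and methoxy at this place, so they leave open where a chlorine, a methyl or a nitrile there would fall. On these data alone, whether the step keeps its size with the dimethylamino group of compound 2 also stays open, since compound 2 appears only with trifluoromethyl.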